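Swapping 1-hydroxy-1-methylethyl for 1-hydroxycyclohexyl at a cytotoxicity limit

A few compounds are considered here, and "the series" means these few. Any claim that something is new, unique, unknown or untested is made for them only; others in the source may bear on it.

- Compound 1 `COc1ccc(C#Cc2cc(Cl)cn3c([N+](=O)[O-])c(CS(=O)(=O)c4ccccc4)nc23)cc1` in an ADME assay on HepG2 cells (Homo sapiens) for cytotoxicity, read by MTT assay, with a stated time of 72 h (a higher number here means that more compound is tolerated, a lower number that less compound is tolerated), gives > 3900 nM as a limit
- Compound 2 `O=[N+]([O-])c1c(CS(=O)(=O)c2ccccc2)nc2c(C#Cc3ccccc3F)cc(Cl)cn12` in this assay gives > 3900 nM as a limit
- Compound 3 `CC(C)(O)C#Cc1cc(Cl)cn2c([N+](=O)[O-])c(CS(=O)(=O)c3ccccc3)nc12` in this assay gives > 62500 nM as a limit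

Compound 3 stands at the limit of > 62500 nM in this assay, at which 1 of the 3 values shown sits, so its position is a limit and not a number. Compound 4 `O=[N+]([O-])c1c(CS(=O)(=O)c2ccccc2)nc2c(C#CC3(O)CCCCC3)cc(Cl)cn12` changes only the group on a triple-bonded carbon: 1-hydroxycyclohexyl in place of 1-hydroxy-1-methylethyl on a triple-bonded carbon with 1-hydroxycyclohexyl in place of 1-hydroxy-1-methylethyl.

Among the measured compounds shown here, two measured steps touch that same carbon. They are a step that the two limits leave unreadable from compound 1 to compound 3 and a step that the two limits leave unreadable from compound 2 to compound 3 so neither offers a size to carry over. Compound 1 also carries a ring in this place and gives > 3900 nM as a limit. Compound 2 also carries a ring there and gives > 3900 nM as a limit. These limits give only a weak hint, since compound 4 keeps the hydroxy group of compound 3 while gaining a ring.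

The expected move is an at least 3.1-fold lower number from compound 3 to compound 4 (0.49 log units; beyond the scatter) toward less compound tolerated, and it is only a rough estimate. For compound 4 the estimate is 20000 nM with an expected range from 5000 nM to 65000 nM in this assay for now.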

Compound 4, half-maximal cytotoxic concentration: > 25000 nM
Compound 4: no number, only a limit (the forecaster's own chance of this, stated with the estimate: 70%); at least 1.2-fold (0.09 log units) between middle value and limit.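

In this assay compound 4 gives > 25000 nM, which is a limit and not a number. Among the compounds shown here, no step from compound 1, compound 2 or compound 3 to compound 4 can be read, as all four values are limits. The compounds shown leave open whether 1-hydroxycyclohexyl in place of 1-hydroxy-1-methylethyl changes the tolerated concentration at all.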